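Cytotoxicity of a Purine Series: Swapping the Side Group

The source may report more compounds than this note shows. Statements on the series, on what has been measured and on what is new or still open speak of the compounds shown alone.

Compound 1 `Nc1nc(OCC(F)(F)F)c2ncn(/C=C3/CC3(CO)CO)c2n1` was tested in an ADME assay on Akata cells (Homo sapiens) for cytotoxicity, with a stated time of 7 days; on this read-out higher numbers stand for lower toxicity in this test and lower numbers for higher toxicity in this test. In this assay compound 1 gives > 20000 nM, which is a limit of the assay rather than a measured number. Two relatives differ from it in one place only. Compound 2 `CN(C)c1nc(N)nc2c1ncn2/C=C1/CC1(CO)CO` carries dimethylamino in place of 2,2,2-trifluoroethoxy; in this assay compound 2 gives > 24000 nM, again a limit. Compound 3 `Nc1nc(NCc2ccccc2)c2ncn(/C=C3/CC3(CO)CO)c2n1` carries benzylamino at the same place; in this assay compound 3 gives > 24000 nM, also a limit. The steps a step that the two limits leave unreadable from compound 1 to compound 2 and a step that the two limits leave unreadable from compound 1 to compound 3 therefore cannot be sized, since every value sits at a limit, one at the limit of > 20000 nM in this assay, at which 1 of the 3 values shown sits, and two at the limit of > 24000 nM in this assay, at which 2 of the 3 values shown sit. Compound 4 `Nc1nc(NC2CC2)c2ncn(/C=C3/CC3(CO)CO)c2n1` differs from compound 1 as follows: cyclopropylamino in place of 2,2,2-trifluoroethoxy on an aromatic carbon. The two measured steps at this place show no readable change, and so no step beyond the scatter is expected for a step that the limit leaves unreadable from compound 1 to compound 4. Compound 4 is expected to give about 24000 nM, within 12000 nM to 48000 nM, most likely reported only as a limit.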

Compound 4, half-maximal cytotoxic concentration: > 20000 nM
Compound 4 was reported as a limit; the forecaster's own chance of this, stated with the estimate: 85%; the middle value does not contradict the limit.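

For the compounds shown here, compound 4 was reported only as a limit, as were compound 1, compound 2 and compound 3, and no step between compound 4 and any of these three can be read. The compounds shown leave open whether swapping the side group changes the result in this assay at all.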